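The source may report more compounds than this note shows. Statements on the series, on what has been measured and on what is new or still open speak of the compounds shown alone.

Working notes on the series in an assay on isolated protein for inhibition of protein kinase C delta type (Homo sapiens), read by TR-FRET, with a stated time of 2 h; on this read-out lower numbers stand for stronger inhibition and higher numbers for weaker inhibition.

Compound 1 `N#Cc1cnc(NCc2cnccc2C(F)(F)F)cc1N[C@H]1CC[C@@H](O)CC1` gives 4500 nM in this assay. Compound 2 `CO[C@H]1CC[C@H](CNc2cc(NCc3cnccc3C(F)(F)F)ncc2C#N)CC1` reaches only the limit > 10000 nM in this assay, a limit and not a number. Compound 3 `N#Cc1cnc(NCc2cnccc2C(F)(F)F)cc1NC1CCOCC1` gives 9800 nM in this assay, the highest of the two numbers shown, with compound 1 the nearest at a 2.2-fold higher number from compound 1 to compound 3 (0.34 log units; beyond the scatter); the step of an at least 1.0-fold lower number from compound 2 to compound 3 (0.00 log units; that floor lies within the scatter) runs into that limit (the limit of > 10000 nM in this assay, at which 1 of the 3 values shown sits).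

Compound 4 `CC1(C)[C@@H](Nc2cc(NCc3cnccc3C(F)(F)F)ncc2C#N)C[C@@H]1C(N)=O` differs from compound 3 in one place: 3-carbamoyl-2,2-dimethylcyclobutyl in place of oxan-4-yl on a nitrogen on an aromatic ring. No measured step replaces oxan-4-yl with a carbamoyl-bearing cyclobutyl, so the steps from compound 1 give only the size of change such exchanges have shown here. Compound 4 is therefore expected near compound 3, with an estimated step of a 1.6-fold lower number from compound 3 to compound 4 (0.21 log units; within the scatter). For compound 4 the estimate is 6000 nM, within 1500 nM to 20000 nM.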

Compound 4, half-maximal inhibitory concentration: > 10000 nM
Compound 4: only a limit was reported; the forecaster's own chance of this, stated with the estimate: 35%; middle value at least 1.6-fold (0.22 log units) from the limit.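

At this position, on a nitrogen on an aromatic ring, 3-carbamoyl-2,2-dimethylcyclobutyl gives no gain over oxan-4-yl, with an at least 1.0-fold higher number from compound 3 to compound 4 (0.00 log units; that floor lies within the scatter), and it stays behind 4-hydroxycyclohexyl, with an at least 2.2-fold higher number from compound 1 to compound 4 (0.34 log units; beyond the scatter). The step between compound 2 and compound 4 cannot be read. Compound 4 gives a limit and not a number, the second in the series: the limit of > 10000 nM in this assay, at which 2 of the 4 values shown sit.

Going by these compounds, how far compound 4 lies past that limit stays open. So does whether an amine or a carboxylic acid on the cyclobutyl in place of the carbamoyl would return a number.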